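Amide-nitrogen substituent: cyclohexyl to pentyl on compound 3

The source may report more compounds than this note shows. Statements on the series, on what has been measured and on what is new or still open speak of the compounds shown alone.

Compound 3 `Cc1nc(N)sc1CCCN/C(N)=N/C(=O)NC1CCCCC1` gives 389 nM in a functional assay on HEK293T cells for agonist activity at histamine H2 receptor (Homo sapiens), read by beta-arrestin recruitment (on this read-out higher numbers stand for an effect only at larger amounts of compound and lower numbers for an effect already at smaller amounts), the highest of the three numbers in hand. Compound 2 `Cc1nc(N)sc1CCCN/C(N)=N/C(=O)NCC(C)CC1CCCCC1` gives 302 nM, which lies within the scatter of compound 3. Among the measured compounds shown here, compound 1 `Cc1nc(N)sc1CCCN/C(N)=N/C(=O)N[C@H](C)c1ccccc1` gives 45.7 nM; the one measured step, an 8.5-fold higher number from compound 1 to compound 3 (0.93 log units; beyond the scatter), is the only change beyond the scatter in the set.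

Compound 4 `CCCCCNC(=O)/N=C(\N)NCCCc1sc(N)nc1C` differs from compound 3 by pentyl in place of cyclohexyl on an amide-type nitrogen. For the measured compounds named here, no measured step covers a ring-to-chain exchange at this nitrogen. The step of an 8.5-fold higher number from compound 1 to compound 3 (0.93 log units; beyond the scatter) concerns a different pair of groups and bears on it only loosely, showing that the amide-nitrogen substituent can move the number substantially. The values of compound 2 and compound 3, both carrying a saturated substituent there and within the scatter of each other, point the other way: a saturated chain of comparable size is expected to change little. Compound 4 is therefore expected near compound 3, with the step of a 1.3-fold higher number from compound 3 to compound 4 (0.11 log units; within the scatter) estimated to stay within the scatter, and a value of about 500 nM (range 200 nM to 1500 nM) is expected.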

Compound 4, half-maximal effective concentration: 178 nM
For compound 4 the middle estimate is 2.8-fold (0.45 log units) above the measured one; the whole stated range lies above it.
By their numbers in this assay, from the lowest: compound 1; then compounds 4, 2 and 3 (each within the scatter of the next, the first and the last beyond it).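

In this assay, pentyl in place of cyclohexyl on the amide-type nitrogen gives a 2.2-fold lower number from compound 3 to compound 4 (0.34 log units; beyond the scatter), so a ring-to-chain exchange at this position moves the number beyond the scatter, although compound 2 and compound 3, both with saturated substituents here, lie within the scatter of each other. The step of a 1.7-fold lower number from compound 2 to compound 4 (0.23 log units; within the scatter) stays within the scatter, so pentyl and the larger cyclohexyl-bearing chain of compound 2 cannot be told apart on this read-out. Pentyl does not match 1-phenylethyl at this nitrogen, as a 3.9-fold higher number from compound 1 to compound 4 (0.59 log units; beyond the scatter) stands beyond the scatter.

Nothing available gives a reason for these steps. Still open, as far as these compounds go, is how a longer chain such as octyl, or a benzyl group, would read on the same nitrogen with the core unchanged.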